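The source may hold more compounds than are shown below. What is called first, only, known or untested is meant among the compounds shown, and "the series" means these compounds.

Measured compounds:
compound 1, `COc1cccc(CSc2nnc(-c3ccc4c(c3)OCCO4)n2-c2ccccc2)c1`, 35100 nM
compound 2, `Cc1ccccc1CSc1nnc(-c2ccc3c(c2)OCCO3)n1-c1ccccc1`, 20500 nM

In a functional assay on HepG2 cells (Homo sapiens) for antiproliferative activity, read by MTT assay, with a stated time of 24 h (a higher number here means a weaker inhibitor, a lower number a stronger inhibitor), compound 1 gives 35100 nM, and compound 2 gives 20500 nM. The two are not separated by more than a 1.7-fold lower number from compound 1 to compound 2 (0.23 log units; within the scatter), so on the numbers shown compound 2 sits alongside compound 1 rather than apart from it. Compound 3, `Brc1ccc(CSc2nnc(-c3ccc4c(c3)OCCO4)n2-c2ccccc2)cc1`, differs from compound 2 by 4-bromophenyl in place of 2-methylphenyl on a saturated chain carbon bound to a sulfur. Within the data shown here, the only measured step, a 1.7-fold lower number from compound 1 to compound 2 (0.23 log units; within the scatter), also exchanged one group at this place without reaching beyond the scatter, so no step beyond the scatter is expected in this assay. Compound 3 is therefore estimated at 22000 nM, between 8000 nM and 60000 nM, an expected step of a 1.1-fold higher number from compound 2 to compound 3 (0.03 log units; within the scatter).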

Compound 3, half-maximal inhibitory concentration: 7940 nM
Estimate against measurement, compound 3: 2.8-fold (0.44 log units) above; the measured number lies below the stated range.
By their numbers in this assay, from the lowest: compound 3; then compounds 2 and 1 (each within the scatter of the next).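

The group on the saturated chain carbon bound to a sulfur can change the number beyond the scatter: 4-bromophenyl gives a 2.6-fold lower number from compound 2 to compound 3 (0.41 log units; beyond the scatter) and a 4.4-fold lower number from compound 1 to compound 3 (0.65 log units; beyond the scatter), both modest steps. Compound 3 therefore stands apart from the other two, which remain within the scatter of each other. Nothing available here explains this difference.

From the compounds shown here alone, whether the bromine itself or its place on the ring matters stays open. Also open, going by these compounds, is how a 4-chlorophenyl, or a phenyl carrying an amine or a carboxylic acid, would read here.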